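A Change of Aryl Group on the Saturated Ring Carbon

The source may report more compounds than this note shows. Statements on the series, on what has been measured and on what is new or still open speak of the compounds shown alone.

Compound 1, `COc1cc(C2=NN(C(C)=O)C(c3ccccc3C(F)(F)F)O2)cc(OC)c1OC`, gives 34.8% in a functional assay on BGC-823 cells (Homo sapiens) for antiproliferative activity, read by MTT assay, tested at 5 uM; a higher number here means a stronger effect of the compound at the concentration tested, a lower number a weaker effect.
Compound 2, `COc1cc(C2=NN(C(C)=O)C(c3ccccc3F)O2)cc(OC)c1OC`, gives 32.8% in this assay.
Compound 3, `COc1cc(C2=NN(C(C)=O)C(c3ccc(Cl)c([N+](=O)[O-])c3)O2)cc(OC)c1OC`, gives 0% in this assay.

Compound 3 stands lowest of the three; both other compounds lie beyond the scatter above it. The next compound is compound 4, `COc1cc(C2=NN(C(C)=O)C(c3ccc(F)c(F)c3)O2)cc(OC)c1OC`. Its difference from compound 3 is this: 3,4-difluorophenyl in place of 4-chloro-3-nitrophenyl on a saturated ring carbon.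

Among the measured compounds shown here, two measured steps bear on this change. Replacing a small halogen-bearing phenyl with the 4-chloro-3-nitrophenyl group cost a great deal, as shown by a number 34.8 percentage points lower from compound 1 to compound 3 (beyond the scatter) and by a number 32.8 percentage points lower from compound 2 to compound 3 (beyond the scatter). The step of a number 2 percentage points lower from compound 1 to compound 2 (within the scatter) shows that swapping one small halogen-type substituent for another made little difference. Going from compound 3 to compound 4 reverses the kind of change that lost the activity, so a large upward step in this assay is expected, though no measured compound carries exactly the 3,4-difluorophenyl group, which widens the range. Compound 4 is therefore estimated at 28%, between 5% and 48%, an expected step of a number 28 percentage points higher from compound 3 to compound 4 (beyond the scatter).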

Compound 4, a percentage reported as inhibition, at one concentration (the size of the read-out at that concentration, not a potency): 21.6%
Beside the measured number, compound 4's estimate is 6.4 percentage points above it; the range from low to high includes it.
By their numbers in this assay, from the lowest: compound 3; then compound 4; then compounds 2 and 1 (each within the scatter of the next).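

The two fluorines restore a clear part of the effect, a number 21.6 percentage points higher from compound 3 to compound 4 (beyond the scatter), so the 4-chloro-3-nitrophenyl and 3,4-difluorophenyl groups, though substituted at the same two numbered ring places, do not behave alike in this assay. Substitution at those places therefore does not by itself remove the effect, yet the 3,4-difluorophenyl group does not match the other two aryl groups, with a number 11.2 percentage points lower from compound 2 to compound 4 (beyond the scatter) and a number 13.2 percentage points lower from compound 1 to compound 4 (beyond the scatter). Nothing measured here explains these differences.

Compound 1 and compound 2 differ from compound 4 in both the number and the placing of their substituents, so these compounds cannot separate those two features. As far as these compounds go, it also remains open how this saturated ring carbon would tolerate a phenyl bearing an amine or a carboxylic acid.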